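A few compounds are considered here, and "the series" means these few. Any claim that something is new, unique, unknown or untested is made for them only; others in the source may bear on it.

Working notes on the series around the shared core of compound 1 `O=C(Nc1ccc(F)c(Cl)c1)c1ccc(F)c(S(=O)(=O)N2CCOC[C@H](O)C2)c1`.

For the measured compounds named here, in an ADME assay on HepG2 2.2.15 cells (Homo sapiens) for cytotoxicity, read by luminescence, with a stated time of 3 days (on this read-out higher numbers stand for lower toxicity in this test and lower numbers for higher toxicity in this test), compound 1 gives 19000 nM, the lowest of the two numbers so far; its nearest neighbour is compound 2 `CN1CCN(S(=O)(=O)c2cc(C(=O)Nc3ccc(F)c(Cl)c3)ccc2F)CC(O)C1` at 31000 nM, and a 1.6-fold higher number from compound 1 to compound 2 (0.21 log units; within the scatter). Compound 3 `CN1CCCN(S(=O)(=O)c2cc(C(=O)Nc3ccc(F)c(Cl)c3)ccc2F)CC1=O` returns only a limit of the assay, > 100000 nM. Against it, an at least 5.2-fold higher number from compound 1 to compound 3 (0.72 log units; beyond the scatter) and an at least 3.2-fold higher number from compound 2 to compound 3 (0.50 log units; beyond the scatter); the relevant point here is the limit of > 100000 nM in this assay, at which 1 of the 3 values shown sits.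

Compound 4 `O=C(Nc1ccc(F)c(Cl)c1)c1ccc(F)c(S(=O)(=O)N2CCOC[C@@H](O)C2)c1` is the next entry. Relative to compound 1 the change is the two compounds have the same atoms and bonds and differ only in configuration as drawn: 1 of 1 stereo elements differ; a stereocentre at a saturated ring carbon is drawn R in compound 1 and S in compound 4. Going by the values given here, none of the measured steps bears on this: each of them exchanges the whole ring on the sulfonyl sulfur, whereas compound 4 keeps the 6-hydroxy-1,4-oxazepan-4-yl ring unchanged apart from the drawn configuration. Without a precedent for a configurational change in this assay, no step beyond the scatter is expected in either direction. Compound 4 is therefore estimated at 19000 nM, within 9500 nM to 38000 nM. The expected step is no change at the digits printed from compound 1 to compound 4 (within the scatter).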

Compound 4, half-maximal cytotoxic concentration: 14000 nM
Compound 4: the middle estimate sits 1.4-fold (0.13 log units) above what was measured; low and high end bracket the measured number.
By their numbers in this assay, from the lowest: compounds 4, 1 and 2 (each within the scatter of the next, the first and the last beyond it). At a limit, above all of these: compound 3.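

In this assay, the first configurational comparison in the series gives a 1.4-fold lower number from compound 1 to compound 4 (0.13 log units; within the scatter), so the drawn configuration at this saturated ring carbon has no readable effect here: the fact that compounds 1 and 4 differ only in the configuration as drawn

The S form does separate from the 6-hydroxy-4-methyl-1,4-diazepan-1-yl ring, with a 2.2-fold lower number from compound 2 to compound 4 (0.35 log units; beyond the scatter), whereas the same ring exchange on the R form stayed within the scatter, so this separation rests on a single pair. The 4-methyl-3-oxo-1,4-diazepan-1-yl ring remains apart, with an at least 7.1-fold lower number from compound 3 to compound 4 (0.85 log units; beyond the scatter), and that step is read against a limit: the limit of > 100000 nM in this assay, at which 1 of the 4 values shown sits.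

On these data alone, it remains open whether configuration is equally silent on the 6-hydroxy-4-methyl-1,4-diazepan-1-yl ring, which compound 2 carries with no configuration drawn. As far as these compounds go, it is also open how an amine or a carboxylic acid would read in place of the hydroxy group on the 6-hydroxy-1,4-oxazepan-4-yl ring.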